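The compounds below may be only part of what the source reports. "The series", "measured", "known", "first", "only" and "open" are said of these compounds alone.

Measured so far:
- compound 1, `Cc1ccc(C(=O)Nc2cn3ncnc3c(CN3CCN(C(=O)C4CCCC4)[C@@H](C)C3)c2C)cn1`: 11 mL.min-1.g-1
- compound 2, `Cc1ccc(C(=O)Nc2cc(F)cc(CN3CCN(C(=O)C4CCCC4)[C@@H](C)C3)c2C)cn1`: 110 mL.min-1.g-1

Both numbers come from an ADME assay on microsomes from liver (Mus musculus) for metabolic stability; on this read-out higher numbers stand for fast clearance and lower numbers for slow clearance. Compound 1 holds the lower of the two numbers; compound 2 sits higher, and the gap between them lies beyond the usual scatter of this assay. Among the compounds with values here, no pair of measured compounds differs in a single place, so no step between measured compounds can be read off, and what each change does to this read-out is so far unknown.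

The next compound, compound 3, `Cc1ccc(C(=O)Nc2cn3ncnc3c(CN3CCN(C(=O)CC(C(F)(F)F)C(F)(F)F)[C@@H](C)C3)c2C)cn1`, is derived from compound 1 by one change: 3,3,3-trifluoro-2-(trifluoromethyl)propyl in place of cyclopentyl on a carbonyl carbon

Within the data shown here, with only two measured numbers and no measured step, the expectation for compound 3 rests on compound 1 alone, whose value is 11 mL.min-1.g-1 in this assay. The expected step from compound 1 to compound 3 is a 1.4-fold lower number from compound 1 to compound 3 (0.14 log units; within the scatter), a move towards slower clearance that stays close to the scatter rather than clearly beyond it. Compound 3 is therefore estimated at 8 mL.min-1.g-1 in this assay, with a likely range from 3 mL.min-1.g-1 to 25 mL.min-1.g-1.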

Compound 3, intrinsic clearance in microsomes in the Mus musculus assay: < 10 mL.min-1.g-1
Compound 3 was reported as a limit; the forecaster's own chance of this, stated with the estimate: 10%; the middle value is on the limit's open side.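

Within the data shown here, in the Mus musculus assay, 3,3,3-trifluoro-2-(trifluoromethyl)propyl in place of cyclopentyl on a carbonyl carbon gives the first step that can be read at this position, an at least 1.1-fold lower number from compound 1 to compound 3 (0.04 log units; that floor lies within the scatter), so on the core of compound 1 this open-chain group does not push the number upwards, while the true size of the step remains unknown. Compound 3 stands in this read-out only as a limit of the assay: the limit of < 10 mL.min-1.g-1 in the Mus musculus assay, at which 1 of the 3 values shown sits.

In a physicochemical assay for solubility, at pH 6.8 (on this read-out higher numbers stand for higher solubility and lower numbers for lower solubility), compound 1 gives 190000 nM and compound 3 gives 200000 nM, two values within the scatter of each other, so this change leaves no readable mark on that read-out either.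

The compounds shown do not tell whether the result belongs to the fluorine atoms or simply to an open chain replacing the ring, a question that a plain isobutyl group on the same carbonyl carbon would address. From the compounds shown here alone, it also remains open whether the same change carries over to the core of compound 2, where the starting number is much higher and a step could be read in full.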